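Series notes: hydroxamic acid amides, step to compound 4

The source may hold more compounds than are shown below. What is called first, only, known or untested is meant among the compounds shown, and "the series" means these compounds.

In a physicochemical assay for lipophilicity (on this read-out lower numbers stand for lower lipophilicity and higher numbers for higher lipophilicity), compound 1 `O=C(N[C@@H](CO)C(=O)NO)c1ccc(C#Cc2ccccc2)cc1` gives 2, compound 2 `O=C(N[C@H](CO)C(=O)NO)c1ccc(C#Cc2ccccc2)cc1` gives 2 and compound 3 `NC[C@H](NC(=O)c1ccc(C#Cc2ccccc2)cc1)C(=O)NO` gives 2. Compound 3 thus stands level with compounds 1 and 2 at the digits shown; the step of no change at the digits printed from compound 1 to compound 3 (within the scatter) and the step of no change at the digits printed from compound 2 to compound 3 (within the scatter) are both within the scatter, as is the step of no change at the digits printed from compound 1 to compound 2 (within the scatter), which is consistent with the fact that compounds 1 and 2 differ only in the configuration as drawn.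

Compound 4 `CC(C)(NC(=O)c1ccc(C#Cc2ccccc2)cc1)C(=O)NO` has not yet been measured in this assay. It differs from compound 3 as follows: a group of 7 heavy atoms (4 carbon, 1 nitrogen, 2 oxygen; no ring) in place of a group of 7 heavy atoms (3 carbon, 2 nitrogen, 2 oxygen; no ring), on an amide-type nitrogen. The measured steps that bear on this place are the step from compound 1 to compound 3 and the step from compound 2 to compound 3, each of which exchanged a group on the same amide-type nitrogen and neither of which moved the read-out beyond the scatter. The exchange in compound 4 goes further, since it removes both the hydroxy and the amino, so a small upward step a number 0.40 log units higher from compound 3 to compound 4 (beyond the scatter) is expected rather than none. Compound 4 is therefore estimated at 2.4, with a range from 1.9 to 3.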

Compound 4, distribution coefficient: 3
Beside the measured number, compound 4's estimate is 0.60 log units below it, within the range that was stated.
By their numbers in this assay, from the lowest: compounds 1, 2 and 3 (each within the scatter of the next); then compound 4.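

In this assay, the step of a number 1.00 log units higher from compound 3 to compound 4 (beyond the scatter) shows that the group on the amide-type nitrogen can move this read-out, as the exchange to 1-(hydroxycarbamoyl)-1-methylethyl goes beyond the scatter, whereas the exchanges among compounds 1, 2 and 3 did not. The steps of a number 1.00 log units higher from compound 2 to compound 4 (beyond the scatter) and a number 1.00 log units higher from compound 1 to compound 4 (beyond the scatter) show the same rise from both drawn configurations of the hydroxy-bearing group. Nothing measured here accounts for the rise.

Whether both methyl groups are needed for a step of this size stays open, since the compounds shown do not separate the two methyl groups of the entering group. As far as these compounds go, how a single methyl, an ethyl chain or a carboxylic acid in that group would read also remains open.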